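Series notes: heteroaryl replacements at the branched carbon

The source may report more compounds than this note shows. Statements on the series, on what has been measured and on what is new or still open speak of the compounds shown alone.

Compound 2 `CC(C)C(c1ccc(-c2ccc3cccc(F)c3c2)[nH]c1=O)N1CCN/C1=N\C#N` gives 38 nM in a functional assay on CHO cells for antagonist activity at prostaglandin E2 receptor EP3 subtype (Homo sapiens), read by cAMP accumulation (on this read-out higher numbers stand for weaker inhibition and lower numbers for stronger inhibition), the higher of the two numbers measured; compound 1 `CC(C)C(Cc1nnc[nH]1)c1ccc(-c2ccc3cccc(F)c3c2)[nH]c1=O` gives 17 nM in this assay. Within the data shown here, the only measured step, a 2.2-fold higher number from compound 1 to compound 2 (0.35 log units; beyond the scatter), is modest. Compound 3 `CC(C)C(c1cnc(N)s1)c1ccc(-c2ccc3cccc(F)c3c2)[nH]c1=O` carries a group of 6 heavy atoms (3 carbon, 2 nitrogen, 1 sulfur; one five-membered aromatic ring with 2 hetero atoms) in place of a group of 8 heavy atoms (4 carbon, 4 nitrogen; one five-membered non-aromatic ring with 2 hetero atoms), on a saturated chain carbon bound to an aromatic carbon and a saturated chain carbon, restoring an aromatic five-membered ring as in compound 1. Given the size of that measured step, compound 3 is expected to return toward the number of compound 1, a shift of a 1.5-fold lower number from compound 2 to compound 3 (0.18 log units; within the scatter) in this assay. The estimated value for compound 3 is 25 nM, with a range of 8 nM to 80 nM.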

Compound 3, half-maximal inhibitory concentration: 39 nM
For compound 3 the middle estimate is 1.6-fold (0.19 log units) below the measured one; measured number inside the range.
By their numbers in this assay, from the lowest: compound 1; then compounds 2 and 3 (each within the scatter of the next).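

In this assay, 2-amino-1,3-thiazol-5-yl on this saturated chain carbon gives no readable separation from the non-aromatic ring group of compound 2 (a 1.0-fold higher number from compound 2 to compound 3 (0.01 log units; within the scatter)). An aromatic five-membered ring at this position therefore does not alone recover the number of compound 1, and a modest gap remains (a 2.3-fold higher number from compound 1 to compound 3 (0.36 log units; beyond the scatter)). No measurement on hand explains this gap.

Compound 1 differs from compound 3 in both ring and methyl link, so their contributions remain unseparated. 4H-1,2,4-triazol-3-yl bound directly, or 2-amino-1,3-thiazol-5-yl on a methyl link, would separate them.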